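Aryl substitution on the piperazine in a fatty-acid amide hydrolase series

The source may hold more compounds than are shown below. What is called first, only, known or untested is meant among the compounds shown, and "the series" means these compounds.

Compound 3 `CC(C)Cc1ccc(C(C)C(=O)N2CCN(c3ccc(Cl)c(Cl)c3)CC2)cc1` gives the highest number of the three measured compounds in an assay on brain for inhibition of Fatty-acid amide hydrolase 1 (Rattus norvegicus), read by scintillation counting, with a stated time of 10 min (on this read-out higher numbers stand for weaker inhibition and lower numbers for stronger inhibition), with 16000 nM. Compound 1 `CC(C)Cc1ccc(C(C)C(=O)N2CCN(c3ccccc3)CC2)cc1` gives 4700 nM and compound 2 `CC(C)Cc1ccc(C(C)C(=O)N2CCN(c3cccc(Cl)c3)CC2)cc1` gives 1700 nM. The next compound, compound 4 `CC(C)Cc1ccc(C(C)C(=O)N2CCN(c3ccc(F)cc3)CC2)cc1`, differs from compound 3 by 4-fluorophenyl in place of 3,4-dichlorophenyl on an amine nitrogen in a ring. Among the measured compounds shown here, two measured steps bear on this change: the exchange of phenyl for 3,4-dichlorophenyl, a 3.4-fold higher number from compound 1 to compound 3 (0.53 log units; beyond the scatter), which would be undone here, and the single chloro addition a 2.8-fold lower number from compound 1 to compound 2 (0.44 log units; beyond the scatter). For the measured compounds named here, no measured pair shows the effect of a 4-fluorophenyl on this nitrogen, so the estimate leans on compound 1 and its 4700 nM. The expected step in this assay is a 4.0-fold lower number from compound 3 to compound 4 (0.60 log units; beyond the scatter). Compound 4 is estimated at 4000 nM, with a range from 1500 nM to 11000 nM.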

Compound 4, half-maximal inhibitory concentration: 17000 nM
The estimate for compound 4 lay 4.3-fold (0.63 log units) below the measured number; measured number outside the range, above it.
By their numbers in this assay, from the lowest: compound 2; then compound 1; then compounds 3 and 4 (each within the scatter of the next).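

Fluoro in place of hydrogen on the aromatic carbon raises the number (a 3.6-fold higher number from compound 1 to compound 4 (0.56 log units; beyond the scatter)), whereas the earlier chloro addition lowered it, so a single halogen on this ring does not act alike in every case. Among the compounds shown here, the 3-chlorophenyl of compound 2 remains the only aryl group here that improves on phenyl (a 10-fold higher number from compound 2 to compound 4 (1.00 log units; beyond the scatter)), and 4-fluorophenyl and 3,4-dichlorophenyl cannot be separated (a 1.1-fold higher number from compound 3 to compound 4 (0.03 log units; within the scatter)). Nothing available gives a reason for these steps. The numbers leave open what 4-chlorophenyl or 4-methoxyphenyl would give on this nitrogen. They also leave open whether the place of the halogen or its identity decides the outcome.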